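The source may hold more compounds than are shown below. What is called first, only, known or untested is meant among the compounds shown, and "the series" means these compounds.

Measured so far:
Compound 1 `O=C(Nc1cccc(-c2nc3ccccc3s2)c1)c1cc([N+](=O)[O-])ccc1Cl`: > 27000 nM (a limit of the assay)
Compound 2 `O=C(Nc1cccc(-c2ccccc2)c1)c1cc([N+](=O)[O-])ccc1Cl`: 22000 nM

Going by the values given here, in an ADME assay on HEK293 cells (Homo sapiens) for cytotoxicity, with a stated time of 72 h (a lower number here means that less compound is needed, a higher number that more compound is needed for the effect), compound 2 gives 22000 nM, the only actual number so far. The entry for compound 1, > 27000 nM, is a limit and not a number. Compound 3 `O=C(Nc1cccc(-c2nc3ccccc3o2)c1)c1cc([N+](=O)[O-])ccc1Cl` differs from compound 2 by 1,3-benzoxazol-2-yl in place of phenyl on an aromatic carbon, with 1,3-benzoxazol-2-yl in place of phenyl on an aromatic carbon. Among the compounds with values here, one measured step bears on this change: an at least 1.2-fold lower number from compound 1 to compound 2 (0.08 log units; that floor lies within the scatter). As far as these compounds go, that step exchanges 1,3-benzothiazol-2-yl for phenyl, so it offers only an indirect guide, and its true size remains open. No change beyond the scatter is therefore expected in this assay, although compound 3 may also return only a limit. The expected step is a 1.1-fold higher number from compound 2 to compound 3 (0.06 log units; within the scatter). Compound 3 is estimated at 25000 nM, with an expected range from 12000 nM to 50000 nM.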

Compound 3, half-maximal effective concentration: > 25000 nM
Compound 3 was reported as a limit (the forecaster's own chance of this, stated with the estimate: 45%); the middle value lies on the limit itself.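

In this assay compound 3 returns a limit, > 25000 nM, and not a number. Replacing phenyl with 1,3-benzoxazol-2-yl on this aromatic carbon, meta to a large group, gives an at least 1.1-fold higher number from compound 2 to compound 3 (0.05 log units; that floor lies within the scatter), so this change shows no step beyond the scatter. The step from compound 1 to compound 3 cannot be read, and both compounds carrying a five-membered aromatic ring with 2 hetero atoms now end in limits, leaving compound 2 with the only actual number: the limit of > 25000 nM in this assay, at which 1 of the 3 values shown sits.

As far as these compounds go, the true values of compound 1 and compound 3 remain open, and so does any comparison between their 1,3-benzothiazol-2-yl and 1,3-benzoxazol-2-yl groups. From the compounds shown here alone, it is also open whether an amine or a carboxylic acid on this aromatic carbon would give an actual number in this assay.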